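Styryl in Place of Phenyl on the Pyrazoline Ring

The source may report more compounds than this note shows. Statements on the series, on what has been measured and on what is new or still open speak of the compounds shown alone.

Compound 1 `CC(=O)N1N=C(c2cccc3ccccc23)CC1c1ccc2ccccc2c1`: 210 nM
Compound 2 `O=CCN1N=C(c2ccc3ccccc3c2)CC1c1ccccc1`: 7400 nM

In a functional assay on PC-3 cells (Homo sapiens) for cytotoxicity, read by sulforhodamine B assay, with a stated time of 48 h (on this read-out higher numbers stand for weaker inhibition and lower numbers for stronger inhibition), compound 2 gives 7400 nM, the higher of the two numbers recorded; compound 1 gives 210 nM. For the measured compounds named here, the two compounds differ in several places, so no single step between them is counted. Compound 3 `O=CCN1N=C(c2ccc3ccccc3c2)CC1/C=C/c1ccccc1` carries the change (2-phenylethenyl in place of phenyl on a saturated ring carbon). Going by the values given here, no measured pair shows what this change does, so the expectation rests on little. A modest step toward a lower number is expected, a 1.9-fold lower number from compound 2 to compound 3 (0.27 log units; within the scatter), but one within the scatter cannot be ruled out. Compound 3 is therefore estimated at 4000 nM, with a range from 1000 nM to 20000 nM.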

Compound 3, half-maximal inhibitory concentration: 19100 nM
The estimate for compound 3 lay 4.8-fold (0.68 log units) below the measured number, and the stated range covers the measured number.
By their numbers in this assay, from the lowest: compound 1; then compound 2; then compound 3.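

In this assay, placing 2-phenylethenyl in place of phenyl on this saturated ring carbon gives a 2.6-fold higher number from compound 2 to compound 3 (0.41 log units; beyond the scatter) and so weakens inhibition. For the compounds shown here, this is the first measured step at this position, and it shows that the number responds to what sits there. Adding the double bond and its two carbons does not help in this pair. Nothing measured here explains this result.

As far as these compounds go, whether an amine or a carboxylic acid on this ring carbon would lower the number remains open. So does whether this change would have the same effect with another group in place of formylmethyl.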